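The compounds below may be only part of what the source reports. "The series", "measured", "known", "first", "only" and "open" are said of these compounds alone.

Compound 1, `Nc1ncnc2c1ncn2CC(O)C(=O)OCCO`, in a functional assay on PRK cells (Oryctolagus cuniculus) for cytotoxicity (on this read-out higher numbers stand for lower toxicity in this test and lower numbers for higher toxicity in this test), gives > 400 ug/mL, a limit of the assay rather than a number.
Compound 2, `CCCCCCCCOC(=O)C(O)Cn1cnc2c(N)ncnc21`, in this assay gives 100 ug/mL.
Compound 3, `COC(=O)C(O)Cn1cnc2c(N)ncnc21`, in this assay gives > 400 ug/mL, again a limit of the assay and not a number.

Compound 3 therefore stands at the top of what the numbers show, together with compound 1: the limit of > 400 ug/mL in this assay, at which 2 of the 3 values shown sit. Between these two nothing can be ordered, and a step that the two limits leave unreadable from compound 1 to compound 3. Against compound 2 the picture is clearer, since an at least 4.0-fold higher number from compound 2 to compound 3 (0.60 log units; beyond the scatter), and likewise an at least 4.0-fold lower number from compound 1 to compound 2 (0.60 log units; beyond the scatter).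

The unmeasured compound 4, `Nc1ncnc2c1ncn2CC(O)C(=O)OC1CCCCC1`, differs from compound 3 in one place: cyclohexyl in place of methyl on an oxygen next to a carbonyl group. The step that bears on it is the one at the same position, between compound 2 and compound 3, where a long chain on the ester oxygen went with the lower number, at least modest in size. Cyclohexyl is larger than methyl but smaller than the heptyl that was removed, so a step of an at least 1.6-fold lower number from compound 3 to compound 4 (0.20 log units; that floor lies within the scatter) is expected, smaller than that measured one and toward compound 2. Compound 4 is accordingly expected to give about 250 ug/mL, within a range from 100 ug/mL to 400 ug/mL, with a fair chance that only a limit is reported.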

Compound 4, minimum cytotoxic concentration: 100 ug/mL
The estimate for compound 4 lay 2.5-fold (0.40 log units) above the measured number; low and high end bracket the measured number.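

At the ester oxygen in this assay, replacing methyl with cyclohexyl gives an at least 4.0-fold lower number from compound 3 to compound 4 (0.60 log units; beyond the scatter) and shows that a long chain is not needed for the number to fall. Set against the octyl ester, the cyclohexyl ester shows no change at the digits printed from compound 2 to compound 4 (within the scatter) and so, at this place, a six-membered ring of carbon and an open chain of eight carbons read alike, which the earlier compounds, with open chains only, could not show. Against 2-hydroxyethyl the picture is the same, with an at least 4.0-fold lower number from compound 1 to compound 4 (0.60 log units; beyond the scatter) as the step, but the values of compound 1 and compound 3 are limits of the assay, so this step and the one from methyl give only a minimum size: the limit of > 400 ug/mL in this assay, at which 2 of the 4 values shown sit.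

Going by these compounds, whether an ethyl or butyl chain on this oxygen already lowers the number, or whether a phenyl ring or a benzyl group reads like cyclohexyl, remains open. On these data alone, how far above the limit compound 1 and compound 3 truly stand also remains open, as does whether an amine or a carboxylic acid on the ester group would keep the number at that limit.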